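Aryl arm swap on the shared core: compound 2 to compound 4

This account rests on a few compounds, and the source may have more. Where it says the series, first, only, none or still open, it means among the compounds named here.

Going by the values given here, compound 2 `COc1cc(-c2ccnc3cc(-c4ccc(C(F)(F)F)cc4)nn23)cc(OC)c1OC` is the only member of this set with a measured number in a functional assay on B16-F0 cells (Mus musculus) for inhibition, read by CCK-8 assay, with a stated time of 48 h; a higher number here means a weaker inhibitor, a lower number a stronger inhibitor: compound 2 gives 1770 nM. Compound 1 `COc1cc(-c2cc3nccc(-c4c[nH]c5ccccc45)n3n2)cc(OC)c1OC` returns only a limit in this assay, namely > 10000 nM. Compound 3 `Cc1ccc(-c2cc3nccc(-c4ccc(F)cc4)n3n2)cc1` likewise returns a limit in this assay, > 10000 nM. Among the compounds with values here, two of the three values shown therefore sit at the limit of > 10000 nM in this assay, at which 2 of the 3 values shown sit, and compound 2 is the one value that stands apart from that limit as a real number.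

Compound 4 `COc1cc(-c2ccnc3cc(-c4ccc(C(C)(C)C)cc4)nn23)cc(OC)c1OC` differs from compound 2 in one place only: tert-butyl in place of trifluoromethyl on an aromatic carbon. Both groups bring no hydrogen-bond donors, no hydrogen-bond acceptors and no net charge, and both sit on an aromatic carbon of a six-membered aromatic ring of carbon only, para to a large group. No measured step of this kind exists among the compounds shown, so the size of the change can only be expected, not read off.

The step from compound 2 to compound 4 in this assay is expected to be a 1.4-fold higher number from compound 2 to compound 4 (0.15 log units; within the scatter), a change not larger than the usual scatter, with no clear direction. Compound 4 is accordingly estimated at 2500 nM in this assay, with a likely range from 800 nM to 8000 nM.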

Compound 4, half-maximal inhibitory concentration: > 10000 nM
Compound 4: only a limit was reported (the forecaster's own chance of this, stated with the estimate: 20%); middle value at least 4.0-fold (0.60 log units) from the limit.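

The series now holds its first one-place step in this assay, with 4-(trifluoromethyl)phenyl giving way to 4-(tert-butyl)phenyl: an at least 5.6-fold higher number from compound 2 to compound 4 (0.75 log units; beyond the scatter). This place on the aromatic ring is therefore not indifferent to the swap: trifluoromethyl and tert-butyl match in what is counted for them, with the same number of heavy atoms, no hydrogen-bond donors or acceptors and no net charge, yet they do not read alike here, so those counts alone do not settle what this place accepts. The step gives a bound and not an exact size, since compound 4 returns only a limit, and compound 2 remains the one compound in the set with a real number: the limit of > 10000 nM in this assay, at which 3 of the 4 values shown sit.

Going by these compounds, the true size of the step stays open, and one pair cannot show whether the result holds on other cores or with other arms. Also open, on these data alone, is how a chlorine, a nitrile, an amine or a carboxylic acid at this place would compare with the trifluoromethyl of compound 2.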